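Swapping a branched chain for a hydroxyl-bearing one

This account rests on a few compounds, and the source may have more. Where it says the series, first, only, none or still open, it means among the compounds named here.

Measured compounds:
compound 1, `CC(C)C/N=c1\c(O)c(O)\c1=N/Cc1ccc(C#N)cc1`, 10200 nM
compound 2, `Cc1cc(Cl)cc(Cl)c1C/N=c1\c(O)c(O)\c1=N/C(C)(C)C`, 220 nM

In a functional assay for inhibition, with Rattus norvegicus as the target (on this read-out lower numbers stand for stronger inhibition and higher numbers for weaker inhibition), compound 1 stands at the higher of the two numbers, a gap from compound 2 that lies beyond the scatter. Compound 2 differs from compound 1 in more than one place, so no single-change step can be read from the pair. Compound 3, `CC(C)(CO)/N=c1\c(O)c(O)\c1=N/Cc1ccc(C#N)cc1`, is not yet measured. It carries 1-(hydroxymethyl)-1-methylethyl in place of isobutyl on a double-bonded nitrogen. Among the compounds with values here, with no measured step of this kind to lean on, the expected step from compound 1 to compound 3 is a 2.0-fold lower number from compound 1 to compound 3 (0.31 log units; beyond the scatter), a modest move toward stronger inhibition that may not exceed the scatter. Compound 3 is estimated at 5000 nM, within 1500 nM to 16000 nM.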

Compound 3, half-maximal inhibitory concentration: 21300 nM
The estimate for compound 3 lay 4.3-fold (0.63 log units) below the measured number; measured number outside the range, above it.
By their numbers in this assay, from the lowest: compound 2; then compound 1; then compound 3.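

In this assay putting 1-(hydroxymethyl)-1-methylethyl in place of isobutyl on the double-bonded nitrogen gives a 2.1-fold higher number from compound 1 to compound 3 (0.32 log units; beyond the scatter) and so modestly weakens inhibition. This first single-change step shows that the position responds to this swap, although the shift lies only just past the usual scatter. Nothing available explains the shift.

This one step cannot separate the effect of the hydroxyl from that of the rearranged carbon chain. Going by these compounds, whether an amine, a carboxylic acid or a longer chain here would give a lower number remains open.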